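Replacing Iodo with (Dimethylamino)methyl

This account rests on a few compounds, and the source may have more. Where it says the series, first, only, none or still open, it means among the compounds named here.

In a physicochemical assay for solubility, at pH 7.4 (a higher number here means a more soluble compound, a lower number a less soluble compound), compound 1 `CNc1nc(NCc2ccc(NC(=O)c3ccc(Cl)nc3)cc2)c2ccccc2n1` reads 23 ug/mL and compound 2 `Cc1ccc2c(NCc3ccc(NC(=O)c4ccc(F)cc4)cc3)nc(N3CCNCC3)nc2c1` reads 22 ug/mL in the same test. Compound 3 `CN(C)c1nc(NCc2ccc(NC(=O)c3ccc(F)cc3)cc2)c2ccc(I)cc2n1` gives > 100 ug/mL as its result, which is a limit and not a number, and it alone of the three stands there. Compound 4 `CN(C)Cc1ccc2c(NCc3ccc(NC(=O)c4ccc(F)cc4)cc3)nc(N(C)C)nc2c1` differs from it in one place (dimethylamino)methyl in place of iodo on an aromatic carbon with (dimethylamino)methyl in place of iodo on an aromatic carbon. Among the compounds with values here, no measured pair shows this change on its own, so the expected step of an at least 1.2-fold lower number from compound 3 to compound 4 (0.09 log units; that floor lies within the scatter) in this assay is only an estimate: a small fall, perhaps none beyond the scatter. For compound 4 the estimated value is 80 ug/mL with an expected range from 25 ug/mL to 150 ug/mL for the measurement.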

Compound 4, solubility: 55 ug/mL
Beside the measured number, compound 4's estimate is 1.5-fold (0.16 log units) above it, and the stated range covers the measured number.
By their numbers in this assay, from the lowest: compounds 2 and 1 (each within the scatter of the next); then compound 4. At a limit, above all of these: compound 3.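

Within the data shown here, putting (dimethylamino)methyl in place of iodo on this aromatic carbon gives the first step that can be read at this position in this assay: an at least 1.8-fold lower number from compound 3 to compound 4 (0.25 log units; that floor lies within the scatter). Compound 4 gives a true reading of 55 ug/mL, so this position now has one measured number. The step is only a floor, and its real size cannot be read, because compound 3 stands at a limit: the limit of > 100 ug/mL in this assay, at which 1 of the 4 values shown sits.

On these data alone, how far compound 3 truly lies from compound 4 stays open. So does how a carboxylic acid or a longer amine chain on this aromatic carbon would read.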